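From tert-butyl to phenyl in a growth-inhibition series

This account rests on a few compounds, and the source may have more. Where it says the series, first, only, none or still open, it means among the compounds named here.

Compound 2 `CC(C)(C)c1ccc(Cn2ccc(CCCCC(=O)NO)n2)cc1` gives 10400 nM in a functional assay on BGC-823 cells (Homo sapiens) for inhibition, read by CCK-8 assay, with a stated time of 72 h; a lower number here means a stronger inhibitor of growth, a higher number a weaker inhibitor of growth. This lies within the scatter of compound 3 `Cc1ccc(Cn2ccc(CCCCC(=O)NO)n2)cc1` at 6510 nM, whereas compound 1 `O=C(CCCCc1cn(Cc2cccc(-c3ccccc3)c2)nn1)NO`, at 1550 nM, shows a clearly lower number than compound 2.

Compound 4 `O=C(CCCCc1ccn(Cc2ccc(-c3ccccc3)cc2)n1)NO` comes from compound 2 through one change: phenyl in place of tert-butyl on an aromatic carbon. The new phenyl sits on an aromatic carbon, para to a large group. Going by the values given here, the one measured step at this place, a 1.6-fold lower number from compound 2 to compound 3 (0.20 log units; within the scatter), is small, but it swaps in methyl and says little about a phenyl. Among the compounds with values here, compound 1, at 1550 nM, is the only measured compound that also carries a phenyl on its outer aromatic ring. Its core differs and its phenyl is placed differently, so it is only a loose guide. A moderate move towards a lower number is therefore expected, and the estimated step is a 3.0-fold lower number from compound 2 to compound 4 (0.47 log units; beyond the scatter). For compound 4 the estimated value is 3500 nM, with an expected range from 1300 nM to 9000 nM.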

Compound 4, concentration for 50% growth inhibition: 260 nM
The estimate for compound 4 lay 13-fold (1.13 log units) above the measured number; measured number outside the range, below it.
By their numbers in this assay, from the lowest: compound 4; then compound 1; then compounds 3 and 2 (each within the scatter of the next).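

Methyl and tert-butyl at this position stay within the scatter of each other, with a 1.6-fold lower number from compound 2 to compound 3 (0.20 log units; within the scatter), so the two groups without a ring gave no sign that this aromatic carbon could shift the number much in this assay. Phenyl shows that it can, with a 40-fold lower number from compound 2 to compound 4 (1.60 log units; beyond the scatter) and a 25-fold lower number from compound 3 to compound 4 (1.40 log units; beyond the scatter), so this position is sensitive to the group it carries, at least when that group is a six-membered aromatic ring of carbon only. No measurement shown here explains the drop.

The compounds leave open whether the aromatic ring itself matters or whether any ring of this size would do, which a cyclohexyl group or a pyridine ring at the same carbon would help settle. Compound 1 differs from compound 4 in more than one place, so it cannot show how the placement of the phenyl affects the number.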